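Compound 3 to compound 4: isobutyl to benzyl

A few compounds are considered here, and "the series" means these few. Any claim that something is new, unique, unknown or untested is made for them only; others in the source may bear on it.

In a functional assay on B16 cells (Mus musculus) for inhibition (on this read-out lower numbers stand for stronger inhibition and higher numbers for weaker inhibition), compound 1 (`CC(C)CN(NC(=O)OCc1ccccc1)C(=O)CN(Cc1ccccc1)NC(=O)CBr`) gives 1400 nM as the lower of the two actual numbers. Compound 2 (`CC(C)CN(NC(=O)OCc1ccccc1)C(=O)CN(Cc1ccccc1)NC(=O)Cc1cccc(Br)c1`) reads > 80000 nM and this is a limit of the assay. Compound 3 (`CC(C)CN(CC(=O)N(CC(C)C)NC(=O)OCc1ccccc1)/N=C/c1ccccc1B(O)O`) gives 26300 nM as the higher actual number. Compound 4 (`CC(C)CN(NC(=O)OCc1ccccc1)C(=O)CN(Cc1ccccc1)/N=C/c1ccccc1B(O)O`) differs from compound 3 (phenyl in place of isopropyl on a saturated chain carbon bound to an amine nitrogen): phenyl in place of isopropyl on a saturated chain carbon bound to an amine nitrogen. For the measured compounds named here, the one measured step (an at least 57-fold higher number from compound 1 to compound 2 (1.75 log units; beyond the scatter)) was large, but it put 3-bromophenyl in place of bromo on a saturated chain carbon bound to a carbonyl carbon and so does not bear on this change. No step beyond the scatter is therefore expected in this assay, and the step expected for compound 4 is small (a 1.3-fold lower number from compound 3 to compound 4 (0.12 log units; within the scatter)). Compound 4 is estimated at 20000 nM with an expected range from 6000 nM to 70000 nM for its value.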

Compound 4, half-maximal inhibitory concentration: 65500 nM
Beside the measured number, compound 4's estimate is 3.3-fold (0.52 log units) below it; low and high end bracket the measured number.
By their numbers in this assay, from the lowest: compound 1; then compound 3; then compound 4. At a limit, above all of these: compound 2.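

In this assay, for the compounds shown here, phenyl in place of isopropyl on a saturated chain carbon bound to an amine nitrogen is the first readable change at this position, and it weakens inhibition modestly: a 2.5-fold higher number from compound 3 to compound 4 (0.40 log units; beyond the scatter). The group on the amine nitrogen matters far more in the benzyl series, with a 47-fold higher number from compound 1 to compound 4 (1.67 log units; beyond the scatter). The remaining step, an at least 1.2-fold lower number from compound 2 to compound 4 (0.08 log units; that floor lies within the scatter), starts from a value that is a limit: the limit of > 80000 nM in this assay, at which 1 of the 4 values shown sits.

With only isopropyl and phenyl compared here, no trend can be drawn for this position. On these data alone, whether cyclohexyl or a longer chain on that carbon moves the value in the same direction stays open.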